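A furan-2-yl swap on the side chain of compound 2

The source may report more compounds than this note shows. Statements on the series, on what has been measured and on what is new or still open speak of the compounds shown alone.

In a physicochemical assay for acid dissociation, compound 1 `COc1cccc(CNCCCNc2ccnc3cc(-c4ccc(C(C)(C)C)cc4)ccc23)c1O` gives 9.47 and compound 2 `COc1cccc(CNCCCNc2ccnc3cc(Cc4cccc(C(F)(F)F)c4)ccc23)c1O` gives 9.47, so the two stand level. Compound 3 `FC(F)(F)c1cccc(Cc2ccc3c(NCCCNCc4ccco4)ccnc3c2)c1` has furan-2-yl in place of 2-hydroxy-3-methoxyphenyl on a saturated chain carbon bound to an amine nitrogen. Among the compounds with values here, the only measured step, no change at the digits printed from compound 1 to compound 2 (within the scatter), was made on an aromatic carbon and leaves this chain carbon untouched, so it offers only weak guidance. A small fall is therefore expected, with wide uncertainty, and the estimated shift is a number 0.37 log units lower from compound 2 to compound 3 (beyond the scatter). For compound 3 the expected value is 9.1, within an estimated range of 8.6 to 9.6.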

Compound 3, acid dissociation constant: 9.47
Beside the measured number, compound 3's estimate is 0.37 log units below it; low and high end bracket the measured number.
By their numbers in this assay, from the lowest: compounds 1, 2 and 3 (each within the scatter of the next).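

In this assay, furan-2-yl in place of 2-hydroxy-3-methoxyphenyl on a saturated chain carbon bound to an amine nitrogen brings no change at the digits printed from compound 2 to compound 3 (within the scatter). The earlier step concerned only an aromatic carbon, whereas this one shows the read-out also holding when this chain group changes to a five-membered aromatic ring with 0 hydrogen-bond donors. Nothing measured here accounts for this result. As far as these compounds go, whether pyridin-2-yl or cyclohexyl at this chain carbon would also leave the read-out unchanged stays open. The compounds also do not show which part of the structure the number reports.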